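A few compounds are considered here, and "the series" means these few. Any claim that something is new, unique, unknown or untested is made for them only; others in the source may bear on it.

Measured so far:
Compound 1, `O=C1c2c[n+]([O-])c3ccccc3c2C(=O)c2c1c1ccccc1n2Cc1cn(C[C@H](O)CO)nn1` — 1130 nM in a toxicity assay on L02 cells (Homo sapiens) for cytotoxicity, read by MTT assay, with a stated time of 72 h; on this read-out lower numbers stand for stronger inhibition and higher numbers for weaker inhibition
Compound 2, `O=C1c2c[n+]([O-])c3ccccc3c2C(=O)c2c1c1ccccc1n2Cc1cn(CC(O)CO)nn1` — 1070 nM in this assay

Compound 2 gives the lowest of the two numbers in this assay, and its nearest neighbour is compound 1, at a 1.1-fold lower number from compound 1 to compound 2 (0.02 log units; within the scatter); the two compounds share every atom and bond and differ only in that one stereocentre is drawn with a configuration in one and without in the other (the fact that one of compounds 1 and 2 is drawn with a defined configuration and the other without, at the place where they differ), so the pair shows no shift beyond the scatter.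

Compound 3, `CN1CCN(CCCCCn2c3c(c4ccccc42)C(=O)c2c[n+]([O-])c4ccccc4c2C3=O)CC1`, is not yet measured. It differs from compound 2 by 4-(4-methylpiperazin-1-yl)butyl in place of 1-(2,3-dihydroxypropyl)-1H-1,2,3-triazol-4-yl on a saturated chain carbon bound to an aromatic nitrogen. Among the compounds with values here, none of the measured steps touches this kind of change: the single step available, from compound 1 to compound 2, concerns only the drawing of a stereocentre and tells nothing about swapping the group on the carbon bound to the aromatic nitrogen. Within the data shown here, with no step to lean on, the expected number for compound 3 is taken from compound 2 and given a wide range. The estimated value for compound 3 in this assay is 1000 nM, between 250 nM and 4000 nM, corresponding to an expected 1.1-fold lower number from compound 2 to compound 3 (0.03 log units; within the scatter).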

Compound 3, half-maximal inhibitory concentration: 1640 nM
Compound 3: the middle estimate sits 1.6-fold (0.21 log units) below what was measured; measured number inside the range.
By their numbers in this assay, from the lowest: compounds 2, 1 and 3 (each within the scatter of the next).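

In this assay the change to 4-(4-methylpiperazin-1-yl)butyl in place of 1-(2,3-dihydroxypropyl)-1H-1,2,3-triazol-4-yl on a saturated chain carbon bound to an aromatic nitrogen gives a 1.5-fold higher number from compound 2 to compound 3 (0.19 log units; within the scatter) and, read from the compound with the drawn stereocentre, a 1.5-fold higher number from compound 1 to compound 3 (0.16 log units; within the scatter) as the same change. Within the data shown here, this is the first step that touches the group itself and not just how a stereocentre is drawn, and it shows that a group with a six-membered non-aromatic ring and no hydrogen-bond donors and a group with a five-membered aromatic ring and 2 hydrogen-bond donors give numbers within the scatter of each other at this place. Nothing available on these compounds accounts for this result or ties it to any property of either group.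

The two groups differ in ring and chain at once, so the compounds shown do not separate the part played by the butyl chain from that of the 4-methylpiperazine. As far as these compounds go, it remains open whether a morpholine, a primary amine, a carboxylic acid or a longer chain at this place would also stay within the scatter of these three compounds.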